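The source may report more compounds than this note shows. Statements on the series, on what has been measured and on what is new or still open speak of the compounds shown alone.

Three compounds share one core and differ only in the group on a carbon with a double bond to nitrogen. Compound 1 `CN(C)CCn1cnnc1-c1cc(Oc2ccc(NC(=O)N/N=C/c3ccc(F)cc3Cl)cc2F)ccn1` gives 510 nM in a functional assay on HT-29 cells (Homo sapiens) for cytotoxicity, read by MTT assay, with a stated time of 72 h (a lower number here means a stronger inhibitor, a higher number a weaker inhibitor), the lowest of the three numbers, yet its gaps to compound 2 `CN(C)CCn1cnnc1-c1cc(Oc2ccc(NC(=O)N/N=C/c3ccc(Cl)cc3)cc2F)ccn1` at 530 nM and to compound 3 `CN(C)CCn1cnnc1-c1cc(Oc2ccc(NC(=O)N/N=C/c3cc(C(C)(C)C)cc(C(C)(C)C)c3O)cc2F)ccn1` at 680 nM both lie within the scatter. Compound 4 `CN(C)CCn1cnnc1-c1cc(Oc2ccc(NC(=O)N/N=C/c3ccc(O)cc3)cc2F)ccn1` carries the change (4-hydroxyphenyl in place of 2-chloro-4-fluorophenyl on a carbon with a double bond to nitrogen). Among the compounds with values here, the one comparable step, a 1.0-fold higher number from compound 1 to compound 2 (0.02 log units; within the scatter), swapped one aryl group for another at this same place and moved nothing beyond the scatter; compound 3, a third variant at the same place, also sits within the scatter of compound 1. Compound 4 is therefore expected to show a step of a 1.2-fold higher number from compound 1 to compound 4 (0.07 log units; within the scatter), nothing beyond the scatter. The estimate for compound 4 is 600 nM, with a range from 250 nM to 1500 nM.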

Compound 4, half-maximal inhibitory concentration: 1920 nM
Estimate against measurement, compound 4: 3.2-fold (0.51 log units) below, and the stated range ends below it.
By their numbers in this assay, from the lowest: compounds 1, 2 and 3 (each within the scatter of the next); then compound 4.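

Within the data shown here, the step of a 3.8-fold higher number from compound 1 to compound 4 (0.58 log units; beyond the scatter) lies beyond the scatter, so this position does not tolerate every aryl group equally, which the earlier compounds did not reveal. The step of a 3.6-fold higher number from compound 2 to compound 4 (0.56 log units; beyond the scatter) is the cleanest comparison, as only hydroxy in place of chloro on an aromatic carbon separates the two compounds. Nothing measured here accounts for this shift. The compounds shown leave open whether the higher number is specific to hydroxy. A methoxy group or an amine on that same aromatic carbon would help to answer this.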